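The source may report more compounds than this note shows. Statements on the series, on what has been measured and on what is new or still open speak of the compounds shown alone.

Measured so far:
- compound 1 `COc1ccc(/C=C2\CCC/C(=C\c3cccc(OC)c3OC)C2=O)c(OC)c1`: > 50000 nM
- compound 2 `COc1ccc(/C=C2\CCC/C(=C\c3cccc(Cl)c3)C2=O)cc1OC`: 11900 nM

Among the compounds with values here, in an ADME assay on NHDF cells (Homo sapiens) for cytotoxicity, read by MTT assay, with a stated time of 72 h (a lower number here means a stronger inhibitor, a higher number a weaker inhibitor), compound 2 gives 11900 nM, the only actual number so far. Compound 1 gives > 50000 nM, which is a limit of the assay and not a number. Within the data shown here, compound 2 therefore cannot be placed by a measured gap against compound 1, and no step between measured compounds is available.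

The next compound is compound 3 `COc1ccc(/C=C2\CCC/C(=C\c3ccc(OC)c(OC)c3)C2=O)cc1`. It has 4-methoxyphenyl in place of 3-chlorophenyl on a double-bonded chain carbon bound to a double-bonded ring carbon.

Like compound 3, compound 1 carries no chlorine, and compound 1 sits at > 50000 nM. This is thin support from a single limit, so only a moderate move towards weaker inhibition is expected. The expected change is a 1.8-fold higher number from compound 2 to compound 3 (0.27 log units; within the scatter). A result within the scatter of compound 2 would not be surprising. For compound 3 the estimated value is 22000 nM, with an expected range of 9000 nM to 50000 nM.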

Compound 3, half-maximal inhibitory concentration: 30900 nM
Compound 3: middle estimate off by 1.4-fold (0.15 log units), on the low side; the range from low to high includes it.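

In this assay, within the data shown here, 4-methoxyphenyl in place of 3-chlorophenyl on a double-bonded chain carbon bound to a double-bonded ring carbon gives a 2.6-fold higher number from compound 2 to compound 3 (0.41 log units; beyond the scatter), the first measured step. Among these compounds, the earlier compounds offered no measured gap, so this is the first indication that the group at this place matters in this cell read-out, with the change here running towards weaker inhibition, though the step is only modest and rests on a single pair. Compound 1 remains a limit of the assay and not a number, so no step involving compound 1 can be read, and its place relative to the other compounds stays undefined: the limit of > 50000 nM in this assay, at which 1 of the 3 values shown sits.

Among the compounds shown here, the single step exchanges the substituent and its printed ring position together, so it cannot show whether the change follows from losing chlorine, gaining methoxy or moving the substituent. The compounds shown leave open how 3-methoxyphenyl and 4-chlorophenyl would read at this place, which would separate those factors, and how a phenyl ring carrying an amine or a carboxylic acid would behave there.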